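From compound 3 to compound 4: one chloro fewer

This account rests on a few compounds, and the source may have more. Where it says the series, first, only, none or still open, it means among the compounds named here.

Compound 1 `CCCn1c(-c2ccc(Cl)cc2)nn(C)c1=S` gives > 12.5 mg/kg (a limit)
Compound 2 `Cn1nc(-c2ccc(F)cc2)n(C)c1=S` gives 0.61 mg/kg (a number)
Compound 3 `Cn1nc(-c2c(Cl)cccc2Cl)n(C)c1=S` gives > 50 mg/kg (a limit)

In a functional assay on the whole organism with Mus musculus as the target (on this read-out lower numbers stand for an effect already at smaller amounts and higher numbers for an effect only at larger amounts of compound), compound 3 gives only a limit (> 50 mg/kg) and no number. Compound 1 also gives only a limit (> 12.5 mg/kg). Compound 4 (`Cn1nc(-c2ccccc2Cl)n(C)c1=S`) carries hydrogen in place of chloro on an aromatic carbon. Going by the values given here, no measured pair shows this single change, so its size can only be judged loosely. Compound 2 gives a real number (0.61 mg/kg), which suggests that the shared core can act at small doses. A sizeable move towards smaller doses is therefore expected, beyond the usual scatter, though another limit remains possible. The expected step is (an at least 8.3-fold lower number from compound 3 to compound 4 (0.92 log units; beyond the scatter)). For compound 4 the estimated value is 6 mg/kg (expected range 1.5 mg/kg to 40 mg/kg).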

Compound 4, dose for half-maximal effect: 0.37 mg/kg
Compound 4: the middle estimate sits 16-fold (1.21 log units) above what was measured; the measured number lies below the stated range.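

Removing one chloro from the aromatic ring has a very large effect in this assay, with an at least 130-fold lower number from compound 3 to compound 4 (2.13 log units; beyond the scatter). A single chloro on this ring is therefore compatible with an effect at small doses, while the second chloro in compound 3 goes with no number at all. The size of this step is only a minimum, since compound 3 gives a limit and not a number: the limit of > 50 mg/kg in this assay, at which 1 of the 4 values shown sits.

The compounds shown leave open whether a methoxy group or an amine could take the place of the chloro that went. They also leave open whether the remaining chloro of compound 4 is needed at all.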